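A few compounds are considered here, and "the series" means these few. Any claim that something is new, unique, unknown or untested is made for them only; others in the source may bear on it.

Measured compounds in the series:

Compound 1 `COCCNc1ccn2nc(-c3ccc(F)cc3)c(-c3ccnc(NC4CCCC4)n3)c2c1`: in an ADME assay on Vero cells (Chlorocebus sabaeus) for cytotoxicity (a higher number here means that more compound is tolerated, a lower number that less compound is tolerated), compound 1 reaches only the limit > 40000 nM.
Compound 2 `COc1ccc(-c2nn3c(NC4CCCC4)cccc3c2-c2ccnc(NC3CCCC3)n2)cc1`: in this assay compound 2 reaches only the limit > 100000 nM.
Compound 3 `COc1ccc(-c2nn3c(Cl)cc(Cl)cc3c2-c2ccnc(NC3CCCC3)n2)cc1`: in this assay compound 3 reaches only the limit > 40000 nM.

Where compound 3 stands: its value in this assay is a limit, not a number. The two other values shown are limits as well; one sits at the limit of > 100000 nM in this assay, at which 1 of the 3 values shown sits, and two at the limit of > 40000 nM in this assay, at which 2 of the 3 values shown sit. Within the data shown here, since no compound in the set gives a number, no step between measured compounds can be sized, and the three entries cannot be ordered against each other.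

Compound 4 `COc1ccc(-c2nn3c(NC4CCCC4)cc(Cl)cc3c2-c2ccnc(NC3CCCC3)n2)cc1` differs from compound 3 by cyclopentylamino in place of chloro on an aromatic carbon. Compound 2 also carries a cyclopentylamino group on its core and likewise sits at a limit in this assay. Among the measured compounds shown here, no measured step is available to set the size of this change, so no shift beyond the scatter is expected, and there is a large chance that compound 4 again gives only a limit rather than a number.

Compound 4 is expected at 60000 nM, with a range of 30000 nM to 150000 nM. The step from compound 3 to compound 4 is estimated as a step that the limit leaves unreadable from compound 3 to compound 4, essentially flat.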

Compound 4, half-maximal cytotoxic concentration: > 40000 nM
Compound 4 ended at the assay's limit; the forecaster's own chance of this, stated with the estimate: 85%; the middle value lies beyond the limit too.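

No new step can be read in this assay: the steps from compound 3 and from compound 2 to compound 4 join values that are limits, not numbers. The compounds shown leave open whether cyclopentylamino in place of chloro on an aromatic carbon, or chloro in place of hydrogen, shifts the tolerated concentration at all.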